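Moving the chlorines on the dichlorophenyl amide

The source may report more compounds than this note shows. Statements on the series, on what has been measured and on what is new or still open speak of the compounds shown alone.

Measured in a functional assay on Vero cells (Chlorocebus sabaeus) for inhibition; on this read-out lower numbers stand for stronger inhibition and higher numbers for weaker inhibition:
- compound 1 `COc1cc(/C=C/C(=O)c2cccc(NC(=O)c3cc(Cl)cc(Cl)c3)c2)ccc1O`: > 50 ug/mL (a limit)
- compound 2 `COc1cc(/C=C/C(=O)c2cccc(N)c2)ccc1O`: 6.02 ug/mL

Compound 1 stands at the limit of > 50 ug/mL in this assay, at which 1 of the 2 values shown sits, so it has a limit and not a number. Compound 3 `COc1cc(/C=C/C(=O)c2cccc(NC(=O)c3ccc(Cl)cc3Cl)c2)ccc1O` is still to be measured, and it carries one change: 2,4-dichlorophenyl in place of 3,5-dichlorophenyl on a carbonyl carbon. For the measured compounds named here, only one measured step bears on this, an at least 8.3-fold lower number from compound 1 to compound 2 (0.91 log units; beyond the scatter). That step removes the whole (3,5-dichlorophenyl)carbonyl, so it shows what losing the group does and not what rearranging it does. Compound 3 keeps the same atoms, and no step beyond the scatter is expected in this assay, with a reading at the limit quite possible. For compound 3 the estimated value is 45 ug/mL, with an expected range of 15 ug/mL to 100 ug/mL. The expected step is an at least 1.1-fold lower number from compound 1 to compound 3 (0.04 log units; that floor lies within the scatter).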

Compound 3, half-maximal inhibitory concentration: 27.2 ug/mL
Beside the measured number, compound 3's estimate is 1.7-fold (0.22 log units) above it; the range from low to high includes it.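

In this assay, compound 3 gives a dichlorophenyl amide of this series a number rather than a limit, and moving the chlorines to the 2,4-dichlorophenyl arrangement gives an at least 1.8-fold lower number from compound 1 to compound 3 (0.26 log units; that floor lies within the scatter). Acylation of the nitrogen still weakens inhibition with this arrangement, at a 4.5-fold higher number from compound 2 to compound 3 (0.65 log units; beyond the scatter), so the weaker reading of the amide relative to the free amine holds for both chlorine patterns shown. The true size of the change from moving the chlorines remains unfixed because compound 1 has only a limit: the limit of > 50 ug/mL in this assay, at which 1 of the 3 values shown sits.

Open, from the compounds shown here alone, is whether a plain phenyl, a single chlorine or a methoxy group on the same carbonyl would read closer to compound 2 or to compound 3. Also open, going by these compounds, is whether a small acetyl on the nitrogen would already give the same weakening.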